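A few compounds are considered here, and "the series" means these few. Any claim that something is new, unique, unknown or untested is made for them only; others in the source may bear on it.

Compound 1 `CC(C)NC(=O)c1cc(Oc2ccc(/C=C/c3ccccn3)cc2)ccn1` carries an isopropyl on the amide-type nitrogen. In a functional assay on HepG2 cells (Homo sapiens) for antiproliferative activity, read by CCK-8 assay, with a stated time of 48 h (a higher number here means a weaker inhibitor, a lower number a stronger inhibitor), compound 1 reaches only the limit > 100000 nM, so no number is available for it (the limit of > 100000 nM in this assay, at which 1 of the 3 values shown sits). Compound 2 `O=C(NC1CC1)c1cc(Oc2ccc(/C=C/c3ccccn3)cc2)ccn1` differs from compound 1 by cyclopropyl in place of isopropyl on an amide-type nitrogen. In this assay compound 2 gives 31000 nM, a step of an at least 3.2-fold lower number from compound 1 to compound 2 (0.50 log units; beyond the scatter). Compound 3 `CC(C)NC(=O)c1cc(Oc2ccc(/C=C/c3ccncc3)cc2)ccn1` keeps the isopropyl and differs from compound 1 in the core by pyridin-4-yl in place of pyridin-2-yl on a double-bonded chain carbon bound to a double-bonded chain carbon. In this assay compound 3 gives 33700 nM, a step of an at least 2.9-fold lower number from compound 1 to compound 3 (0.47 log units; beyond the scatter). Compounds 2 and 3 sit within the usual scatter of each other, so no order between them is read.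

Compound 4 `O=C(NC1CC1)c1cc(Oc2ccc(/C=C/c3ccncc3)cc2)ccn1` is not yet measured. From compound 3 it differs by cyclopropyl in place of isopropyl on an amide-type nitrogen, the same change as from compound 1 to compound 2, at the same place, an amide-type nitrogen whose other neighbour is a carbonyl carbon; the two pairs differ only in their cores, as described for compound 1 against compound 3. The earlier step is an at least 3.2-fold lower number from compound 1 to compound 2 (0.50 log units; beyond the scatter). Because compound 1 sits at the limit (the limit of > 100000 nM in this assay, at which 1 of the 3 values shown sits), only a lower bound of that step is known, not its size. Compound 4 is expected to give a step of a 2.6-fold lower number from compound 3 to compound 4 (0.41 log units; beyond the scatter), a little short of that bound, weighed against the usual scatter. Going by the values given here, the expectation rests on the single earlier pair and on compound 3 at 33700 nM as the starting point. Compound 4 is therefore expected at about 13000 nM, between 5000 nM and 35000 nM.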

Compound 4, half-maximal inhibitory concentration: 77500 nM
For compound 4 the middle estimate is 6.0-fold (0.78 log units) below the measured one; measured number above the stated range.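

In this assay, cyclopropyl in place of isopropyl on the amide-type nitrogen gives a 2.3-fold higher number from compound 3 to compound 4 (0.36 log units; beyond the scatter), which runs opposite to the earlier step on the core of compound 1: the same change on two cores in this assay, an at least 3.2-fold lower number (0.50 log units; beyond the scatter) from compound 1 to compound 2 and a 2.3-fold higher number (0.36 log units; beyond the scatter) from compound 3 to compound 4, at least 7.4-fold (0.87 log units) apart, beyond the scatter of two such steps

Pyridin-4-yl in place of pyridin-2-yl gives a 2.5-fold higher number from compound 2 to compound 4 (0.40 log units; beyond the scatter), which likewise runs opposite to the earlier step with the isopropyl amide, so neither change carries from one partner to the other in this small set: the same change on two cores in this assay, an at least 2.9-fold lower number (0.47 log units; beyond the scatter) from compound 1 to compound 3 and a 2.5-fold higher number (0.40 log units; beyond the scatter) from compound 2 to compound 4, at least 7.4-fold (0.87 log units) apart, beyond the scatter of two such steps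

Compound 1 stands only at a limit, so the earlier steps and the gaps are known only as bounds, and these four compounds give neither a reason for the reversal nor a rule for any further core: the limit of > 100000 nM in this assay, at which 1 of the 4 values shown sits.

Open, as far as these compounds go, is whether a cyclobutyl or a longer chain such as n-butyl on the amide-type nitrogen would follow the direction seen with the pyridin-2-yl compounds or with the pyridin-4-yl compounds. Also open, from the compounds shown here alone, is where a pyridin-3-yl group would fall, and whether the reversal would persist with it.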